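Extending the Side Chain of Compound 1 Toward Compound 4

This account rests on a few compounds, and the source may have more. Where it says the series, first, only, none or still open, it means among the compounds named here.

Measured so far:
compound 1, `Cc1c(F)c(N)c2c(=O)cc(-c3ccc(N)c(F)c3)oc2c1F`, > 100000 nM
compound 2, `Nc1ccc(-c2cc(=O)c3c(N)c(F)c(Br)c(F)c3o2)cc1F`, > 100000 nM
compound 3, `CCCCCC(=O)OCc1c(F)c(N)c2c(=O)cc(-c3ccc(N)c(F)c3)oc2c1F`, 34000 nM

In a functional assay on HeLa cells (Homo sapiens) for cytotoxicity, read by neutral red uptake, with a stated time of 3 days (a higher number here means a weaker inhibitor, a lower number a stronger inhibitor), compound 1 stands only at a limit of the assay, with > 100000 nM and no number behind it. Compound 2 also stands only at a limit in this assay, with > 100000 nM. Compound 2 carries bromo in place of methyl on an aromatic carbon, and the step that the two limits leave unreadable from compound 1 to compound 2 cannot be read, since (the limit of > 100000 nM in this assay, at which 2 of the 3 values shown sit). For the measured compounds named here, compound 3 is the one measured compound with a real number: in this assay compound 3 gives 34000 nM. It carries (pentylcarbonyl)oxy in place of hydrogen on a saturated chain carbon bound to an aromatic carbon, and the step of an at least 2.9-fold lower number from compound 1 to compound 3 (0.46 log units; beyond the scatter); the matching step an at least 2.9-fold lower number from compound 2 to compound 3 (0.46 log units; beyond the scatter).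

Compound 4 is `CN(C)CCCOCc1c(F)c(N)c2c(=O)cc(-c3ccc(N)c(F)c3)oc2c1F`. It differs from compound 1 as follows: 3-(dimethylamino)propoxy in place of hydrogen on a saturated chain carbon bound to an aromatic carbon. Going by the values given here, the one measured step that bears on this change is an at least 2.9-fold lower number from compound 1 to compound 3 (0.46 log units; beyond the scatter), where a chain was likewise attached at the same saturated carbon and the number fell at least modestly. A similar, at least modest fall is therefore expected here, so that compound 4 is estimated to give 40000 nM, within 10000 nM to 120000 nM. The expected step is an at least 2.5-fold lower number from compound 1 to compound 4 (0.39 log units; beyond the scatter).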

Compound 4, half-maximal inhibitory concentration: 12000 nM
Beside the measured number, compound 4's estimate is 3.3-fold (0.52 log units) above it; measured number inside the range.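

In this assay, the saturated chain carbon bound to an aromatic carbon has now taken two different chains, and both lower the number, so the fall is not tied to the (pentylcarbonyl)oxy group of compound 3: the 3-(dimethylamino)propoxy chain gives an at least 8.3-fold lower number from compound 1 to compound 4 (0.92 log units; beyond the scatter), and the comparison with the bromo compound gives an at least 8.3-fold lower number from compound 2 to compound 4 (0.92 log units; beyond the scatter). For the compounds shown here, the first comparison between two real numbers at this position also shows that the chain itself matters, as 3-(dimethylamino)propyl in place of pentylcarbonyl on the oxygen gives a 2.8-fold lower number from compound 3 to compound 4 (0.45 log units; beyond the scatter), which makes compound 4 the strongest inhibitor of the four. The two larger steps give only a lower bound on size, as each starts from a compound that stands at a limit of the assay and not at a number: the limit of > 100000 nM in this assay, at which 2 of the 4 values shown sit.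

The compounds shown leave open whether the dimethylamino end or the chain as a whole drives the lower number, which a plain pentyloxy chain with no amine, or a carboxylic acid at the chain end, would help to separate. They also leave open whether a longer chain carrying the same amine would lower the number further.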